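Working notes on the aryl substituent and cell toxicity

A few compounds are considered here, and "the series" means these few. Any claim that something is new, unique, unknown or untested is made for them only; others in the source may bear on it.

The three measured compounds share one core and differ only in the group on the aryl ring: compound 1 `CCOC(=O)C1=C(C)N/C(=C/c2cc(C)n(-c3ccc(Cl)cc3)c2C)C1=O` carries chloro, compound 2 `CCOC(=O)C1=C(C)N/C(=C/c2cc(C)n(-c3ccc(S(=O)(=O)C(F)(F)F)cc3)c2C)C1=O` carries (trifluoromethyl)sulfonyl, and compound 3 `CCOC(=O)C1=C(C)N/C(=C/c2cc(C)n(-c3ccc([S+](C)[O-])cc3)c2C)C1=O` carries a group of three heavy atoms built from carbon, oxygen and sulfur. In an ADME assay on L6 cells (Rattus norvegicus) for cytotoxicity, read by resazurin assay, with a stated time of 72 h (a lower number here means that less compound is needed, a higher number that more compound is needed for the effect), compound 1 gives 100000 nM, compound 2 gives 120000 nM and compound 3 gives 220000 nM. Compound 3 stands highest of the three numbers, though only narrowly: a 1.8-fold higher number from compound 2 to compound 3 (0.26 log units; within the scatter), while a 2.2-fold higher number from compound 1 to compound 3 (0.34 log units; beyond the scatter) and a 1.2-fold higher number from compound 1 to compound 2 (0.08 log units; within the scatter).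

Compound 4 `CCOC(=O)C1=C(C)N/C(=C/c2cc(C)n(-c3ccc(CN4CCCCC4)cc3)c2C)C1=O` is not yet measured. Relative to compound 3 the change is a group of 7 heavy atoms (6 carbon, 1 nitrogen; one six-membered non-aromatic ring with 1 hetero atom) in place of a group of 3 heavy atoms (1 carbon, 1 oxygen, 1 sulfur; no ring), on an aromatic carbon. For the measured compounds named here, none of the measured steps contains the entering group; the steps that bear on the position are those that exchanged the leaving group against chloro or (trifluoromethyl)sulfonyl, and both moved this assay by little. With all three numbers sitting in a narrow band, no step beyond the scatter is expected, so the estimated step is a 2.0-fold lower number from compound 3 to compound 4 (0.30 log units; within the scatter). For compound 4 the expected value in this assay is 110000 nM, with a range from 30000 nM to 300000 nM.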

Compound 4, half-maximal effective concentration: 81000 nM
The estimate for compound 4 lay 1.4-fold (0.13 log units) above the measured number; low and high end bracket the measured number.
By their numbers in this assay, from the lowest: compounds 4, 1, 2 and 3 (each within the scatter of the next, the first and the last beyond it).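

In this assay, for the compounds shown here, (piperidin-1-yl)methyl is the first group at this position to carry a ring, and it gives a 2.7-fold lower number from compound 3 to compound 4 (0.43 log units; beyond the scatter), so compound 3 now stands apart from two compounds by more than the scatter. Going by these compounds alone, the same exchange does not separate compound 4 from the other two: the readings are a 1.5-fold lower number from compound 2 to compound 4 (0.17 log units; within the scatter) and a 1.2-fold lower number from compound 1 to compound 4 (0.09 log units; within the scatter), which places (piperidin-1-yl)methyl in one band with chloro and (trifluoromethyl)sulfonyl, and leaves compound 3 as the only member of the four involved in a step beyond the scatter. No supporting measurement is available to explain why compound 3 differs from compound 4.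

The compounds shown leave open whether an open-chain amine such as diethylaminomethyl, or a carboxylic acid, on this aromatic carbon would fall in the same band as compound 1 , compound 2 and compound 4 . They also leave open whether methylsulfonyl, which keeps the sulfur and methyl of the group in compound 3 , would stand with compound 3 or with the others.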